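The source may hold more compounds than are shown below. What is called first, only, known or untested is meant among the compounds shown, and "the series" means these compounds.

The series shares the core of compound 1 `C=CC1=C(C(=O)NCc2ccc(C)cc2)C(c2ccc(OC)cc2)OC1`. In a functional assay on A549 cells (Homo sapiens) for cytotoxicity, read by MTT assay, with a stated time of 24 h (on this read-out lower numbers stand for stronger inhibition and higher numbers for weaker inhibition), compound 1 gives only a limit, > 100000 nM. Compound 2 `C=CC1=C(C(=O)Nc2ccc(C)cc2)C(c2ccc(OC)cc2)OC1` carries 4-methylphenyl in place of 4-methylbenzyl on an amide-type nitrogen. In this assay compound 2 likewise returns only a limit, > 100000 nM. Among the compounds with values here, compound 3 `C=CC1=C(C(=O)Nc2ccc(OCC)cc2)C(c2ccc(OC)cc2)OC1` is the sole member with a number; in this assay compound 3 gives 17600 nM. The readable steps are an at least 5.6-fold lower number from compound 1 to compound 3 (0.75 log units; beyond the scatter) and an at least 5.6-fold lower number from compound 2 to compound 3 (0.75 log units; beyond the scatter), whereas a step that the two limits leave unreadable from compound 1 to compound 2. Compound 2 therefore stands at the weak end of what is shown, sitting at the limit of > 100000 nM in this assay, at which 2 of the 3 values shown sit, together with compound 1.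

Compound 4 `C=CC1=C(C(=O)O)C(c2ccc(OC)cc2)OC1` differs from compound 2 by hydroxy in place of (4-methylphenyl)amino on a carbonyl carbon. Within the data shown here, none of the measured steps bears directly on this change: each alters the substituent on the amide-type nitrogen or its aromatic carbon, and none removes the amide altogether. Among the measured compounds shown here, the one number in the set, that of compound 3, came from a larger aryl substituent, not from loss of it. The expected step is a number no higher from compound 2 to compound 4 (the limit leaves the size open), no shift beyond the scatter. Compound 4 is estimated at 100000 nM, in a range from 30000 nM to 300000 nM, most likely reported as a limit again.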

Compound 4, half-maximal inhibitory concentration: > 100000 nM
Compound 4: no number, only a limit (the forecaster's own chance of this, stated with the estimate: 75%); the middle value sits exactly at the limit.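

In this assay compound 4 gives only a limit, > 100000 nM, and compound 2 also gives only a limit, so no step can be read between compound 2 and compound 4. The compounds shown leave open whether hydroxy and (4-methylphenyl)amino on the carbonyl carbon differ at all in this read-out.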